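Adding a chloro group to the fused ring of compound 3

The compounds below may be only part of what the source reports. "The series", "measured", "known", "first", "only" and "open" are said of these compounds alone.

Measured compounds:
- compound 1, `O=C(Nc1nc2ccc(Cl)cc2s1)c1cn(-c2ccccc2)nc1-c1ccccc1`: 7670 nM
- compound 2, `O=C(Nc1nc2ccccc2s1)c1cn(-c2ccccc2)nc1-c1ccc(F)cc1`: 9010 nM
- compound 3, `O=C(Nc1nc2ccccc2s1)c1cn(-c2ccccc2)nc1-c1ccc(Cl)cc1`: 10300 nM

In a functional assay on A549 cells (Homo sapiens) for cytotoxicity, read by MTT assay, with a stated time of 72 h (a lower number here means a stronger inhibitor, a higher number a weaker inhibitor), compound 3 gives 10300 nM, the highest of the three numbers, though its gaps to compound 2 and to compound 1 both fall within the scatter, so no order among them can be read. Among the measured compounds shown here, the only single-point step known is a 1.1-fold higher number from compound 2 to compound 3 (0.06 log units; within the scatter), a change on the outer phenyl ring that left the number essentially where it was.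

Compound 4, `O=C(Nc1nc2ccc(Cl)cc2s1)c1cn(-c2ccccc2)nc1-c1ccc(Cl)cc1`, differs from compound 3 by chloro in place of hydrogen on an aromatic carbon. For the measured compounds named here, no measured pair isolates this change: compound 1 carries the same chloro group on the fused ring but lacks the chloro on the outer phenyl, so it differs from compound 3 in two places. In this assay compound 1 gives 7670 nM. Compound 3 gives 10300 nM, and the two numbers lie within the scatter of each other.

With nothing suggesting a real shift, compound 4 is expected to show a step of a 1.2-fold lower number from compound 3 to compound 4 (0.08 log units; within the scatter) in this assay, that is, none beyond the scatter, and its estimated value is 8500 nM, with a range from 4000 nM to 18000 nM.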

Compound 4, half-maximal inhibitory concentration: 4360 nM
For compound 4 the middle estimate is 1.9-fold (0.29 log units) above the measured one; the range from low to high includes it.
By their numbers in this assay, from the lowest: compounds 4, 1, 2 and 3 (each within the scatter of the next, the first and the last beyond it).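

In this assay, among the compounds shown here, adding the chloro that turns 1,3-benzothiazol-2-yl into 6-chloro-1,3-benzothiazol-2-yl gives a 2.4-fold lower number from compound 3 to compound 4 (0.37 log units; beyond the scatter), the first single-change step here to lie beyond the scatter, so this position on the fused ring can affect the number when the outer phenyl already carries a chloro. The other single change, a chloro on the outer phenyl, gives a 1.8-fold lower number from compound 1 to compound 4 (0.25 log units; within the scatter), which stays within the scatter and so shows no clear effect when the fused-ring chloro is present. Nothing available explains how the fused-ring chloro produces its step.

The compounds shown leave open whether the fused-ring chloro gives a similar step when the outer phenyl carries fluoro or no substituent. They also leave open how a methoxy group or an amine would compare with chloro at this position.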